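The source may report more compounds than this note shows. Statements on the series, on what has been measured and on what is new or still open speak of the compounds shown alone.

Among the compounds with values here, the three compounds measured so far share one core and differ only in the group on an oxygen next to a carbonyl group. Compound 1 `C[C@@H](O)[C@H]1C(=O)N2C(C(=O)OCOC(=O)OC(C)(C)C)=C(S[C@@H]3CN[C@H](C(=O)Nc4cccc(C(=O)O)c4)C3)[C@H](C)[C@H]12` carries tert-butyl at that place. In a physicochemical assay for metabolic stability, read by LC-MS, in phosphate buffer, with a stated time of 3 h, at pH 7.4, tested at 50 uM (on this read-out lower numbers stand for a less stable compound and higher numbers for a more stable compound), compound 1 gives > 95%, which is a limit of the assay and not a number. Compound 2 `C[C@@H](O)[C@H]1C(=O)N2C(C(=O)OCOC(=O)OC3CCCCC3)=C(S[C@@H]3CN[C@H](C(=O)Nc4cccc(C(=O)O)c4)C3)[C@H](C)[C@H]12` carries cyclohexyl there. In this assay compound 2 gives > 95%, again a limit. Compound 3 `CCOC(=O)OCOC(=O)C1=C(S[C@@H]2CN[C@H](C(=O)Nc3cccc(C(=O)O)c3)C2)[C@H](C)[C@@H]2[C@@H]([C@@H](C)O)C(=O)N12` carries ethyl there. In this assay compound 3 gives > 95%, once more a limit. Compound 2 therefore stands where every measured compound stands, because each of them sits at the limit of > 95% in this assay, at which 3 of the 3 values shown sit. The three steps among them, a step that the two limits leave unreadable from compound 1 to compound 2, a step that the two limits leave unreadable from compound 1 to compound 3 and a step that the two limits leave unreadable from compound 2 to compound 3, cannot be sized.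

Compound 4 `C[C@@H](O)[C@H]1C(=O)N2C(C(=O)OCOC(=O)OC3CCCCC3)=C(S[C@@H]3CN[C@H](C(=O)Nc4cccc(C(=O)OCOC(=O)OC5CCCCC5)c4)C3)[C@H](C)[C@H]12` is built from compound 2 by ((cyclohexyloxycarbonyl)oxy)methyl in place of hydrogen on an oxygen next to a carbonyl group. The same group already present in compound 2 left it at a limit, and the change simply adds a second copy of it. The step from compound 2 to compound 4 is expected to be a step that the limit leaves unreadable from compound 2 to compound 4 in this assay, that is, no step beyond the scatter. Compound 4 is therefore estimated at 96%, within 88% to 100%, most likely reported again as a limit.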

Compound 4, percent of the compound remaining: > 95%
Compound 4: only a limit was reported (the forecaster's own chance of this, stated with the estimate: 80%); the middle value does not contradict the limit.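

In this assay compound 4 gives > 95%, which is a limit and not a number. The step between compound 2 and compound 4 therefore cannot be read, and no new step comes from this result: the limit of > 95% in this assay, at which 4 of the 4 values shown sit.

The compounds shown leave open whether they differ from one another at all in this assay.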